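This account rests on a few compounds, and the source may have more. Where it says the series, first, only, none or still open, it means among the compounds named here.

Measured compounds in a functional assay on HCT-116 cells (Homo sapiens) for cytotoxicity, read by MTT assay, with a stated time of 48 h; a lower number here means a stronger inhibitor, a higher number a weaker inhibitor:
- compound 1 `CCOc1ccc(NC(=O)c2cn(-c3ccccc3)nc2-c2ccccc2)cc1` — 620 nM
- compound 2 `O=C(Nc1ccccc1)c1cn(-c2ccccc2)nc1-c1ccc(Cl)cc1` — 2180 nM
- compound 3 `COc1ccc(NC(=O)c2cn(-c3ccccc3)nc2-c2ccc(Cl)cc2)cc1` — 1330 nM

Compound 3 stands second highest of the three numbers. Its nearest neighbour is compound 2, and that step, a 1.6-fold lower number from compound 2 to compound 3 (0.21 log units; within the scatter), is within the scatter. Compound 1 is the furthest, with a lower number than compound 3, but the two structures differ in two places, so only the two values themselves can be compared.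

Compound 4 `CCOc1ccc(NC(=O)c2cn(-c3ccccc3)nc2-c2ccc(Cl)cc2)cc1` is the next structure. It differs from compound 3 by methyl in place of hydrogen on a saturated chain carbon bound to an oxygen on an aromatic ring; read one bond further out, this is methoxy to ethoxy on the 4-methoxyphenyl ring. Going by the values given here, no measured pair isolates this change. Among the compounds with values here, the one step that touches this part of the molecule, the step from compound 2 to compound 3, only adds the methoxy group, and it lies within the scatter. Compound 1 carries the ethoxy group but on a different core, so it offers only a value, not a step.

With nothing directly bearing on the change, the expected movement in this assay is small: compound 4 is estimated at 1000 nM, within 450 nM to 2200 nM, a step of a 1.3-fold lower number from compound 3 to compound 4 (0.12 log units; within the scatter) that is expected to remain within the scatter.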

Compound 4, half-maximal inhibitory concentration: 420 nM
For compound 4 the middle estimate is 2.4-fold (0.38 log units) above the measured one; the whole stated range lies above it.
By their numbers in this assay, from the lowest: compounds 4 and 1 (each within the scatter of the next); then compounds 3 and 2 (each within the scatter of the next).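

In this assay, extending methoxy to ethoxy gives a 3.2-fold lower number from compound 3 to compound 4 (0.50 log units; beyond the scatter) and so shows that this saturated chain carbon bound to an oxygen on an aromatic ring is a place where one added methyl can move the number beyond the scatter, which a 1.6-fold lower number from compound 2 to compound 3 (0.21 log units; within the scatter) gave no sign of for methoxy itself. Adding the whole ethoxy group gives a 5.2-fold lower number from compound 2 to compound 4 (0.72 log units; beyond the scatter), a step beyond the scatter, while the chloro group in the ethoxy pair gives a 1.5-fold lower number from compound 1 to compound 4 (0.17 log units; within the scatter) and so leaves no readable difference between those two compounds. Nothing available accounts for why one methyl at this place produces a step beyond the scatter.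

The compounds shown leave open whether the trend from methoxy to ethoxy goes on with a longer chain such as propoxy or butoxy, or stops at ethoxy. They also leave open what a branched isopropoxy group or an amine at this place on the ring would do, and whether the step from methoxy to ethoxy keeps its size on the core without the chloro group.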